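This account rests on a few compounds, and the source may have more. Where it says the series, first, only, none or still open, it means among the compounds named here.

Compound 2 `CN(C(=O)NC(=O)c1ccc(C(F)(F)F)cc1)c1nc(C(F)(F)F)c(C(=O)N/N=C/c2cccc(C(F)(F)F)c2)s1` in a functional assay on MCF7 cells (Homo sapiens) for inhibition, read by MTT assay, with a stated time of 72 h (on this read-out higher numbers stand for weaker inhibition and lower numbers for stronger inhibition), gives 8.95 ug/mL. Among the values reported as numbers it stands highest of two; the nearest is compound 3 `CN(C(=O)NC(=O)c1ccc(C(F)(F)F)cc1)c1nc(C(F)(F)F)c(C(=O)N/N=C/c2cc(C(F)(F)F)cc(C(F)(F)F)c2)s1`, which in this assay gives 7.37 ug/mL, and the step of a 1.2-fold lower number from compound 2 to compound 3 (0.08 log units; within the scatter) is small. Compound 1 `CN(C(=O)NC(=O)c1ccc(C(F)(F)F)cc1)c1nc(C(F)(F)F)c(C(=O)N/N=C/c2ccc(C(F)(F)F)cc2)s1` in this assay gives only a limit, > 100 ug/mL. The step of an at least 11-fold lower number from compound 1 to compound 2 (1.04 log units; beyond the scatter) is the one large move in the set, and it rests on a limit (the limit of > 100 ug/mL in this assay, at which 1 of the 3 values shown sits).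

Compound 4 `CN(C(=O)NC(=O)c1ccccc1F)c1nc(C(F)(F)F)c(C(=O)N/N=C/c2cccc(C(F)(F)F)c2)s1` differs from compound 2 in 2-fluorophenyl in place of 4-(trifluoromethyl)phenyl on a carbonyl carbon. Neither measured step touches this position: both an at least 11-fold lower number from compound 1 to compound 2 (1.04 log units; beyond the scatter) and a 1.2-fold lower number from compound 2 to compound 3 (0.08 log units; within the scatter) alter the aryl group on the carbon with a double bond to nitrogen, not the aryl on the carbonyl carbon. Within the data shown here, no measured step therefore bears directly on the change to compound 4, and the expectation is a step of a 1.0-fold higher number from compound 2 to compound 4 (0.00 log units; within the scatter) that stays within the scatter. On that basis compound 4 is estimated at 9 ug/mL, with a range from 3 ug/mL to 30 ug/mL.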

Compound 4, half-maximal inhibitory concentration: 20.5 ug/mL
Compound 4: middle estimate off by 2.3-fold (0.36 log units), on the low side; the measured number falls inside the stated range.
By their numbers in this assay, from the lowest: compounds 3 and 2 (each within the scatter of the next); then compound 4. At a limit, above all of these: compound 1.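

With 2-fluorophenyl in place of 4-(trifluoromethyl)phenyl on the carbonyl carbon, this assay gives a 2.3-fold higher number from compound 2 to compound 4 (0.36 log units; beyond the scatter). Among these compounds, this is the first measured change at this position: the number responds to the aryl group carried there, yet the step is modest and compound 4 still gives a numerical value. The swap alters both the substituent and its place on the ring, and nothing measured here separates these two changes or accounts for the step.

From the compounds shown here alone, it remains open whether a plain phenyl, a 4-fluorophenyl or a 2-(trifluoromethyl)phenyl on the carbonyl carbon would give a number closer to that of compound 2 or compound 4. Also open, going by these compounds, is how a methoxy group, an amine or a carboxylic acid on that aryl ring would read in this assay.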